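Chloro to Bromo Exchange in Two Matched Pairs

The source may hold more compounds than are shown below. What is called first, only, known or untested is meant among the compounds shown, and "the series" means these compounds.

Compound 1 `O=[N+]([O-])c1ccc2[nH]cc(C(c3ccc(Cl)cc3)c3c[nH]c4ccc([N+](=O)[O-])cc34)c2c1` and compound 2 `O=[N+]([O-])c1ccc2[nH]cc(C(c3ccc(Br)cc3)c3c[nH]c4ccc([N+](=O)[O-])cc34)c2c1` share one core and differ only in the halogen on the pendant ring. Compound 3 `N#Cc1ccc2[nH]cc(C(c3ccc(Cl)cc3)c3c[nH]c4ccc(C#N)cc34)c2c1` and compound 4 `N#Cc1ccc2[nH]cc(C(c3ccc(Br)cc3)c3c[nH]c4ccc(C#N)cc34)c2c1` share a second core and differ in the same way. How the core of compound 3 differs from the core of compound 1 is not broken down here.

In a functional assay on HeLa cells (Homo sapiens) for inhibition, read by MTT assay, with a stated time of 48 h (on this read-out higher numbers stand for weaker inhibition and lower numbers for stronger inhibition), compound 1 gives > 100000 nM, which is a limit of the assay and not a number. Compound 2 likewise reaches only a limit in this assay, giving > 100000 nM. Compound 3 also returns a limit in this assay, with > 100000 nM.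

The change from compound 1 to compound 2 is bromo in place of chloro on an aromatic carbon. The step that the two limits leave unreadable from compound 1 to compound 2 cannot be sized because the limit of > 100000 nM in this assay, at which 3 of the 3 values shown sit, holds both of its values, so this pair says nothing about the direction or the size of the halogen swap.

The change from compound 3 to compound 4 is bromo in place of chloro on an aromatic carbon, the same change at the same place. Among the compounds with values here, since the one measured example of it gives no readable step, the expectation rests on compound 3 alone, whose value in this assay is a limit. Compound 4 is therefore expected to sit at or beyond the same limit, with an estimated step that the limit leaves unreadable from compound 3 to compound 4 that cannot be confirmed if both values are limits. The estimate for compound 4 in this assay is 150000 nM, with a range from 40000 nM to 600000 nM.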

Compound 4, half-maximal inhibitory concentration: > 100000 nM
Compound 4 ended at the assay's limit; the forecaster's own chance of this, stated with the estimate: 85%; the middle value is on the limit's open side.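

No step can be read between compound 3 and compound 4 in this assay, because both values are limits and not numbers: the limit of > 100000 nM in this assay, at which 4 of the 4 values shown sit.

The compounds shown leave open how strongly any of compound 1, compound 2, compound 3 or compound 4 acts in this assay and whether the change from 4-chlorophenyl to 4-bromophenyl shifts the read-out at all, in either direction.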